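The compounds below may be only part of what the source reports. "The series", "measured", "known", "first", "only" and "open" are said of these compounds alone.

Compound 1 `O=c1[nH]cc(S(=O)(=O)Nc2ccccc2-c2cn(-c3ccccc3)nn2)c(=O)[nH]1` and compound 3 `O=c1[nH]cc(S(=O)(=O)Nc2ccc(-c3cn(-c4ccccc4)nn3)cc2)c(=O)[nH]1` are built from the same atoms joined differently; the difference between their two cores is not broken down here. In a functional assay on A549 cells (Homo sapiens) for antiproliferative activity, read by MTT assay, with a stated time of 24 h (a lower number here means a stronger inhibitor, a higher number a weaker inhibitor), compound 1 gives 6790 nM, and in this assay compound 3 gives 7170 nM. These two numbers lie within the usual scatter of each other, so nothing separates them.

Compound 2 `Cc1cccc(-n2cc(-c3ccccc3NS(=O)(=O)c3c[nH]c(=O)[nH]c3=O)nn2)c1` differs from compound 1 only by methyl in place of hydrogen on an aromatic carbon. In this assay compound 2 gives 1870 nM, which means a 3.6-fold lower number from compound 1 to compound 2 (0.56 log units; beyond the scatter).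

Compound 4 `Cc1ccccc1-n1cc(-c2ccc(NS(=O)(=O)c3c[nH]c(=O)[nH]c3=O)cc2)nn1` has not yet been measured. It differs from compound 3 by methyl in place of hydrogen on an aromatic carbon. Among the compounds with values here, this is the same kind of change as the one from compound 1 to compound 2, but not the same change: in compound 2 the added methyl sits meta to a large group, whereas in compound 4 it sits ortho to a large group, and the two starting cores differ as noted above. A lower number is expected for compound 4 because a 3.6-fold lower number from compound 1 to compound 2 (0.56 log units; beyond the scatter) shows the added methyl helping on the other core, but the expected step is kept smaller since neither the place nor the core is the same. The step from compound 3 to compound 4 is therefore estimated as a 2.0-fold lower number from compound 3 to compound 4 (0.31 log units; beyond the scatter). For compound 4 in this assay the estimate is 3500 nM, expected to fall between 1500 nM and 8000 nM.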

Compound 4, half-maximal inhibitory concentration: 3130 nM
Compound 4: middle estimate off by 1.1-fold (0.05 log units), on the high side; measured number inside the range.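

In this assay, the change from phenyl to 2-methylphenyl gives a 2.3-fold lower number from compound 3 to compound 4 (0.36 log units; beyond the scatter), so adding a methyl lowers the number on this core too, and the step is larger than the usual scatter of repeated measurements. Set beside the earlier step, the two results point the same way and cannot be told apart in size: the same change on two cores in this assay, a 3.6-fold lower number (0.56 log units; beyond the scatter) from compound 1 to compound 2 and a 2.3-fold lower number (0.36 log units; beyond the scatter) from compound 3 to compound 4, 1.6-fold (0.20 log units) apart, within the scatter of two such steps. Within the data shown here, this shows that the benefit of the methyl carried over between these two cores, but it rests on only two pairs of compounds, and the methyl does not occupy the same place in compound 2 as in compound 4, where it sits ortho to a large group, so the pairs cannot show that the core has no influence on the step or separate the influence of the core from that of the methyl's place.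

The compounds shown leave open whether a methyl in exactly the same place on both cores would give matching steps. They also leave open whether a different group at that spot, such as an ethyl chain, a methoxy group, a chlorine atom, an amine or a carboxylic acid, would lower the number further, leave it unchanged or raise it.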